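Cytotoxicity notes on the thienyl imine series

The compounds below may be only part of what the source reports. "The series", "measured", "known", "first", "only" and "open" are said of these compounds alone.

Measured compounds:
compound 1 `Clc1ccc(/C=N/c2sc3c(c2-c2nc4ccccc4s2)CCCC3)c(Cl)c1`: 56.6 ug/mL
compound 2 `FC(F)(F)c1ccc(/C=N/c2sc3c(c2-c2nc4ccccc4s2)CCCC3)cc1`: 250 ug/mL

For the measured compounds named here, in an ADME assay on cells (Rhabdomyosarcoma cell, Homo sapiens) for cytotoxicity, read by MTT assay, with a stated time of 72 h (on this read-out higher numbers stand for lower toxicity in this test and lower numbers for higher toxicity in this test), compound 2 stands highest of the two numbers; its nearest neighbour is compound 1, and the only measured step, a 4.4-fold higher number from compound 1 to compound 2 (0.65 log units; beyond the scatter), is modest but beyond the scatter. Compound 3 `C(=C/c1ccccc1)\C=N\c1sc2c(c1-c1nc3ccccc3s1)CCCC2` is not yet measured. It differs from compound 2 by 2-phenylethenyl in place of 4-(trifluoromethyl)phenyl on a carbon with a double bond to nitrogen. Going by the values given here, no measured step covers this exchange; the one step at hand, a 4.4-fold higher number from compound 1 to compound 2 (0.65 log units; beyond the scatter), swaps one aryl group for another on the same carbon with a double bond to nitrogen, so it bears on the position only, not on the change itself. An entering group of a different kind gives no firm direction. Compound 3 is therefore expected to land between the two measured numbers, with the estimate 120 ug/mL and a range from 40 ug/mL to 300 ug/mL. This estimate means a step of a 2.1-fold lower number from compound 2 to compound 3 (0.32 log units; beyond the scatter), expected to be a modest downward move.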

Compound 3, half-maximal cytotoxic concentration: 207 ug/mL
Beside the measured number, compound 3's estimate is 1.7-fold (0.24 log units) below it; low and high end bracket the measured number.
By their numbers in this assay, from the lowest: compound 1; then compounds 3 and 2 (each within the scatter of the next).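

In this assay the step of a 1.2-fold lower number from compound 2 to compound 3 (0.08 log units; within the scatter) shows that this carbon with a double bond to nitrogen can carry 2-phenylethenyl instead of 4-(trifluoromethyl)phenyl with no change that can be read, although the entering group has a double bond outside aromatic rings and no fluorine. With a 3.7-fold higher number from compound 1 to compound 3 (0.56 log units; beyond the scatter) as a second step beyond the scatter, compound 1, with its 2,4-dichlorophenyl, now stands apart as the lowest of the three numbers, and no longer against a single partner. Nothing at hand bears on the cause of these differences.

On these data alone, whether a methylamino group or a carboxylic acid on the phenyl ring would keep the number in the range of compound 2 and compound 3 remains open. So does the outcome for a longer chain, such as a hexyl chain, on the same carbon.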